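The source may hold more compounds than are shown below. What is called first, only, known or untested is meant among the compounds shown, and "the series" means these compounds.

Measured compounds:
Compound 1 `Cc1ccccc1CN1CC=C(CCC(=O)NO)C1=O`: 4280 nM in a functional assay on NUGC-3 cells (Homo sapiens) for inhibition, read by sulforhodamine B assay; on this read-out higher numbers stand for weaker inhibition of growth and lower numbers for stronger inhibition of growth.
Compound 2 `O=C(CCC1=CCN(Cc2cccc(Br)c2)C1=O)NO`: 4280 nM in this assay.

Compound 2 stands level with compound 1 at the digits shown; the two values lie within the scatter of one another, so no order is read between them. Compound 3 `N#Cc1cccc(CN2CC=C(CCC(=O)NO)C2=O)c1` is not yet measured. It differs from compound 2 by cyano in place of bromo on an aromatic carbon. Within the data shown here, no step between measured compounds bears on this exchange, so the expectation rests on the position of compound 2 alone: a step no larger than the scatter is expected, with no settled direction. Compound 3 is expected near 4500 nM, within 1800 nM to 12000 nM. The expected step of a 1.1-fold higher number from compound 2 to compound 3 (0.02 log units; within the scatter) is accordingly small.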

Compound 3, concentration for 50% growth inhibition: 4120 nM
Beside the measured number, compound 3's estimate is 1.1-fold (0.04 log units) above it; the measured number falls inside the stated range.
By their numbers in this assay, from the lowest: compounds 3, 1 and 2 (each within the scatter of the next).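

In this assay, cyano in place of bromo on an aromatic carbon, meta to a large group, gives a 1.0-fold lower number from compound 2 to compound 3 (0.02 log units; within the scatter) and so leaves the read-out unmoved within the scatter. Among these compounds, this is the first step read at this position: one heavy atom gives way to two, and a triple bond and a hydrogen-bond acceptor enter, with no separation in growth inhibition. Nothing on hand explains this result.

As far as these compounds go, whether an amine or a carboxylic acid on this aromatic carbon would hold the number at this level stays open. So does the outcome of the same exchange elsewhere on the ring.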